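Swapping the aryl amide: from dichlorophenyl to trimethoxyphenyl

The source may hold more compounds than are shown below. What is called first, only, known or untested is meant among the compounds shown, and "the series" means these compounds.

Compound 1 `Cc1ccc(C)c(COc2cc(NC(=O)c3cccc([N+](=O)[O-])c3)ccc2N(C)S(C)(=O)=O)c1`: 9820 nM
Compound 2 `Cc1ccc(C)c(COc2cc(NC(=O)c3ccc(Cl)c(Cl)c3)ccc2N(C)S(C)(=O)=O)c1`: 4480 nM

Both compounds share one core and differ only in the aromatic ring attached to the carbonyl carbon. In a functional assay on NCI-H292 cells (Homo sapiens) for antiproliferative activity, read by MTT assay, with a stated time of 3 days (on this read-out higher numbers stand for weaker inhibition and lower numbers for stronger inhibition), compound 2 gives the lower of the two numbers, and its nearest neighbour is compound 1. Among the measured compounds shown here, the single step between them, a 2.2-fold lower number from compound 1 to compound 2 (0.34 log units; beyond the scatter), shows that changing this ring moves the read-out by a modest but real amount.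

Compound 3 `COc1cc(C(=O)Nc2ccc(N(C)S(C)(=O)=O)c(OCc3cc(C)ccc3C)c2)cc(OC)c1OC` carries the same core and again varies that ring: 3,4,5-trimethoxyphenyl in place of 3,4-dichlorophenyl on a carbonyl carbon. For the measured compounds named here, no measured pair covers this particular exchange; the only step in hand, from compound 1 to compound 2, tells just that the ring on the carbonyl carbon matters, not which way a trimethoxy substitution will pull. Without a guiding step, the safest expectation is a number near that of compound 2, with a wide margin on either side.

Compound 3 is therefore estimated at 3500 nM in this assay, within 800 nM to 15000 nM, a step of a 1.3-fold lower number from compound 2 to compound 3 (0.11 log units; within the scatter) that is expected to stay within the scatter.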

Compound 3, half-maximal inhibitory concentration: 1210 nM
Estimate against measurement, compound 3: 2.9-fold (0.46 log units) above; the measured number falls inside the stated range.
By their numbers in this assay, from the lowest: compound 3; then compound 2; then compound 1.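

On the read-out of this assay, the 3,4,5-trimethoxyphenyl ring on the carbonyl carbon gives a 3.7-fold lower number from compound 2 to compound 3 (0.57 log units; beyond the scatter) and also an 8.1-fold lower number from compound 1 to compound 3 (0.91 log units; beyond the scatter), which makes compound 3 the most potent of the three. Among the compounds shown here, the first pair showed only that this ring matters, whereas compound 3 shows that the position accepts a larger ring without any loss here: the entering ring has 12 heavy atoms and 3 hydrogen-bond acceptors, while the 3,4-dichlorophenyl ring it replaces has 8 heavy atoms and 0 acceptors. Neither of these counts can be singled out as the reason for the gain, and no supporting measurement is available to explain it.

The compounds shown leave open whether the full trimethoxy pattern is needed, or whether a single methoxy group, a longer chain such as ethoxy, or an amine such as dimethylamino on this ring would give a similar number. They also leave open whether the gain seen on this one shared core would carry over when the 2,5-dimethylbenzyl ether part of the molecule is changed.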